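Swapping chloro for methyl at compound 3

This account rests on a few compounds, and the source may have more. Where it says the series, first, only, none or still open, it means among the compounds named here.

Measured so far in a functional assay on HepG2 cells (Homo sapiens) for cytotoxicity, read by MTT assay, with a stated time of 72 h (on this read-out higher numbers stand for weaker inhibition and lower numbers for stronger inhibition), are three compounds:
- compound 1 `CNC(=O)c1cc(Oc2ccc(/C=C/C(=O)c3ccc(Br)cc3)cc2)ccn1` gives 22000 nM
- compound 2 `CNC(=O)c1cc(Oc2ccc(/C=C/C(=O)c3ccc([N+](=O)[O-])cc3)cc2)ccn1` gives 41400 nM
- compound 3 `CNC(=O)c1cc(Oc2ccc(/C=C/C(=O)c3ccc(Cl)cc3)cc2)ccn1` gives 36600 nM

Compound 3, at 36600 nM, cannot be separated from either neighbour in this assay. The gaps are a 1.7-fold higher number from compound 1 to compound 3 (0.22 log units; within the scatter) and a 1.1-fold lower number from compound 2 to compound 3 (0.05 log units; within the scatter), so no order can be read among these compounds.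

The next compound is compound 4 `CNC(=O)c1cc(Oc2ccc(/C=C/C(=O)c3ccc(C)cc3)cc2)ccn1`, which puts methyl in place of chloro on an aromatic carbon, para to a large group, turning 4-chlorophenyl into 4-methylphenyl: methyl in place of chloro on an aromatic carbon. Among the compounds with values here, no measured step covers this exact exchange. The closest evidence comes from the other changes at the same place on the ring. These are a 1.7-fold higher number from compound 1 to compound 3 (0.22 log units; within the scatter), a 1.9-fold higher number from compound 1 to compound 2 (0.27 log units; within the scatter) and a 1.1-fold lower number from compound 2 to compound 3 (0.05 log units; within the scatter), and all three stay within the scatter. Bromo, chloro and nitro thus give values that cannot be told apart, and the same is expected of methyl, though none of these compounds tests it directly. No step beyond the scatter is expected, in either direction.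

The expected change is a 1.1-fold lower number from compound 3 to compound 4 (0.06 log units; within the scatter). Compound 4 is estimated at 32000 nM, with an expected range of 16000 nM to 62000 nM.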

Compound 4, half-maximal inhibitory concentration: > 50000 nM
Compound 4: a limit, no number (the forecaster's own chance of this, stated with the estimate: 8%); middle value at least 1.5-fold (0.19 log units) away from the limit.
By their numbers in this assay, from the lowest: compounds 1, 3 and 2 (each within the scatter of the next). At a limit, above all of these: compound 4.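

In this assay compound 4 gives no number, only a limit of the assay: the limit of > 50000 nM in this assay, at which 1 of the 4 values shown sits.

Even so, this position no longer looks indifferent to every group, as it did while bromo, chloro and nitro could not be told apart: methyl in place of bromo gives an at least 2.2-fold higher number from compound 1 to compound 4 (0.35 log units; beyond the scatter), the first step at this place on the ring that lies beyond the scatter. Against the other two compounds, the floors of the steps stay within the scatter, at an at least 1.3-fold higher number from compound 3 to compound 4 (0.13 log units; that floor lies within the scatter) and an at least 1.2-fold higher number from compound 2 to compound 4 (0.08 log units; that floor lies within the scatter), so the exchange of chloro for methyl that was in question is not shown to matter on its own, and methyl stands apart only from compound 1.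

As far as these compounds go, how far compound 4 lies past its limit remains unknown, and with it whether methyl truly differs from chloro and nitro. Also open, from the compounds shown here alone, is whether an amine, a methoxy group or a carboxylic acid at this place on the ring would read like the halogens or reach the same limit.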